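Swapping trifluoromethyl for methoxy on the pendant ring

The source may report more compounds than this note shows. Statements on the series, on what has been measured and on what is new or still open speak of the compounds shown alone.

In a functional assay on SGC-7901 cells (Homo sapiens) for antiproliferative activity, read by MTT assay, with a stated time of 72 h (a higher number here means a weaker inhibitor, a lower number a stronger inhibitor), compound 3 `COc1cc(-n2cnc3ccc(-c4ccc(C(F)(F)F)cc4)cc32)cc(OC)c1OC` gives 890 nM, the highest of the two numbers reported. Compound 1 `COc1cc(-n2cnc3ccc(-c4cccc(N)c4)cc32)cc(OC)c1OC` gives 21 nM in this assay. Compound 2 `COc1cc(-c2ccc3ncn(-c4cc(OC)c(OC)c(OC)c4)c3c2)cc(OC)c1OC` reaches only a limit of this assay, > 10000 nM, and no number. Compound 4 `COc1cccc(-c2ccc3ncn(-c4cc(OC)c(OC)c(OC)c4)c3c2)c1` differs from compound 3 by 3-methoxyphenyl in place of 4-(trifluoromethyl)phenyl on an aromatic carbon. Going by the values given here, the single measured step, a 42-fold higher number from compound 1 to compound 3 (1.63 log units; beyond the scatter), alters both the group and its place on the pendant ring, so it offers only a loose guide; the pendant ring of compound 4 carries a 3-methoxyphenyl rather than the 3-aminophenyl of compound 1 or the 4-(trifluoromethyl)phenyl of compound 3. A moderate downward move is expected, a 4.5-fold lower number from compound 3 to compound 4 (0.65 log units; beyond the scatter), giving an estimate for compound 4 of 200 nM, within 40 nM to 1500 nM.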

Compound 4, half-maximal inhibitory concentration: 3310 nM
The estimate for compound 4 lay 17-fold (1.22 log units) below the measured number; measured number above the stated range.
By their numbers in this assay, from the lowest: compound 1; then compound 3; then compound 4. At a limit, above all of these: compound 2.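

With the place on the pendant ring held and only amino exchanged for methoxy, the change is a 160-fold higher number from compound 1 to compound 4 (2.20 log units; beyond the scatter) in this assay and so isolates the group itself, which the earlier step could not do. Against the trifluoromethyl compound the move is smaller, a 3.7-fold higher number from compound 3 to compound 4 (0.57 log units; beyond the scatter) in this assay and with group and place changed together. No measurement shown gives a reason for either loss. As far as these compounds go, whether the amino group is specifically required stays open, since a hydroxyl group or a dimethylamino group in its place would test this.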